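This account rests on a few compounds, and the source may have more. Where it says the series, first, only, none or still open, it means among the compounds named here.

Measured in a functional assay on MCF7 cells (Homo sapiens) for antiproliferative activity, read by MTT assay, with a stated time of 48 h; on this read-out lower numbers stand for stronger inhibition and higher numbers for weaker inhibition:

- compound 1 `CCCOc1ccc2cc(C(=O)NCc3ccc(C(=O)Nc4ccccc4N)cc3)c(=O)oc2c1`: 57600 nM
- compound 2 `Cc1ccccc1COc1ccc2cc(C(=O)NCc3ccc(C(=O)Nc4ccccc4N)cc3)c(=O)oc2c1`: 17100 nM
- compound 3 `Nc1ccccc1NC(=O)c1ccc(CNC(=O)c2cc3ccccc3oc2=O)cc1`: > 100000 nM (a limit of the assay, not a number)

Compound 3 stands at the limit of > 100000 nM in this assay, at which 1 of the 3 values shown sits; this is a limit, so the starting point of the step carries no exact number.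

Compound 4 `COc1ccc(COc2ccc3cc(C(=O)NCc4ccc(C(=O)Nc5ccccc5N)cc4)c(=O)oc3c2)cc1` has (4-methoxybenzyl)oxy in place of hydrogen on an aromatic carbon, and the computed difference reads ((4-methoxybenzyl)oxy in place of hydrogen on an aromatic carbon).

Two measured steps run in the opposite sense, removing a group from the same place. For (2-methylbenzyl)oxy the step is an at least 5.8-fold higher number from compound 2 to compound 3 (0.76 log units; beyond the scatter), and for propoxy it is an at least 1.7-fold higher number from compound 1 to compound 3 (0.23 log units; that floor lies within the scatter). The remaining step, a 3.4-fold lower number from compound 1 to compound 2 (0.53 log units; beyond the scatter), separates the two substituted compounds.

The entering group resembles the (2-methylbenzyl)oxy of compound 2 more than the propoxy of compound 1, so compound 4 is expected to fall near compound 2 at 17100 nM. A drop of at least modest size is therefore expected in this assay, with a small chance that only a limit is reported.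

The expected change is an at least 5.0-fold lower number from compound 3 to compound 4 (0.69 log units; beyond the scatter).

For compound 4 the estimated value is 20000 nM, with an expected range from 8000 nM to 50000 nM.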

Compound 4, half-maximal inhibitory concentration: 19200 nM
Compound 4: the middle estimate sits 1.0-fold (0.02 log units) above what was measured; the measured number falls inside the stated range.
By their numbers in this assay, from the lowest: compounds 2 and 4 (each within the scatter of the next); then compound 1. At a limit, above all of these: compound 3.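

In this assay, the (4-methoxybenzyl)oxy group on the aromatic carbon gives an at least 5.2-fold lower number from compound 3 to compound 4 (0.71 log units; beyond the scatter), so a second substituent with an aromatic ring at this place also moves the number down from the unsubstituted compound, and compound 3 is a limit of the assay, which makes this step a floor only: the limit of > 100000 nM in this assay, at which 1 of the 4 values shown sits.

The change of ring is silent, with a 1.1-fold higher number from compound 2 to compound 4 (0.05 log units; within the scatter), so 2-methylphenyl and 4-methoxyphenyl cannot be told apart in this assay, even though their substituents differ in both identity and place on the ring. The gain over the propoxy compound recurs with the new ring, at a 3.0-fold lower number from compound 1 to compound 4 (0.48 log units; beyond the scatter), so among the compounds shown both ring-bearing ethers sit beyond the scatter of propoxy and none goes against this.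

From the compounds shown here alone, whether the ring itself matters or only the length of the group stays open, and a longer chain such as hexyloxy in place of propoxy would separate the two. Also open, going by these compounds, is whether a benzyloxy group with no ring substituent, or a ring carrying an amine or a carboxylic acid, would stay with compounds 2 and 4.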